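The source may report more compounds than this note shows. Statements on the series, on what has been measured and on what is new or still open speak of the compounds shown alone.

Measured compounds:
compound 1 `CSc1ccc(OCc2ccc(F)cc2F)c(C2=C(c3cccc(C(=O)O)c3)CCC2)c1` gives 15.9 nM in an assay on isolated protein for inhibition of prostaglandin E2 receptor EP1 subtype (Homo sapiens); a lower number here means a stronger inhibitor, a higher number a weaker inhibitor
compound 2 `CSc1ccc(OCc2ccccc2)c(C2=C(c3cccc(C(=O)O)c3)CCC2)c1` gives 63.1 nM in this assay
compound 3 `CS(=O)(=O)c1ccc(OCc2ccc(F)cc2F)c(C2=C(c3cccc(C(=O)O)c3)CCC2)c1` gives 15.9 nM in this assay

The three compounds share one core, varied at two places. From compound 1 to compound 2 the change is phenyl in place of 2,4-difluorophenyl on a saturated chain carbon bound to an oxygen on an aromatic ring, and in this assay it produced a 4.0-fold higher number from compound 1 to compound 2 (0.60 log units; beyond the scatter). The cores of compound 1 and compound 3 differ by methylsulfonyl in place of methylsulfanyl on an aromatic carbon, and this gave no change at the digits printed from compound 1 to compound 3 (within the scatter), so compound 3 stands level with compound 1 and the two share the lowest number of the three.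

Compound 4 `CS(=O)(=O)c1ccc(OCc2ccccc2)c(C2=C(c3cccc(C(=O)O)c3)CCC2)c1` has not yet been measured. It differs from compound 3 by phenyl in place of 2,4-difluorophenyl on a saturated chain carbon bound to an oxygen on an aromatic ring, the same change that was made from compound 1 to compound 2, at the same place. Because the core change gave no change at the digits printed from compound 1 to compound 3 (within the scatter), the earlier step is expected to carry over, and compound 4 is expected to show a 4.0-fold higher number from compound 3 to compound 4 (0.60 log units; beyond the scatter) in this assay, beside the earlier step of a 4.0-fold higher number from compound 1 to compound 2 (0.60 log units; beyond the scatter). The estimate for compound 4 in this assay is therefore 63 nM, expected to lie between 25 nM and 160 nM.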

Compound 4, half-maximal inhibitory concentration: 79.4 nM
For compound 4 the middle estimate is 1.3-fold (0.10 log units) below the measured one; low and high end bracket the measured number.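

In this assay, for the compounds shown here, phenyl in place of 2,4-difluorophenyl on the methylsulfonyl core gave a 5.0-fold higher number from compound 3 to compound 4 (0.70 log units; beyond the scatter), and this step agrees with the one seen on the methylsulfanyl core: the same change on two cores in this assay, a 4.0-fold higher number (0.60 log units; beyond the scatter) from compound 1 to compound 2 and a 5.0-fold higher number (0.70 log units; beyond the scatter) from compound 3 to compound 4, 1.3-fold (0.10 log units) apart, within the scatter of two such steps Methylsulfonyl in place of methylsulfanyl on the phenyl core gave a 1.3-fold higher number from compound 2 to compound 4 (0.10 log units; within the scatter), and this change also reads alike on both cores: the same change on two cores in this assay, no change at the digits printed (within the scatter) from compound 1 to compound 3 and a 1.3-fold higher number (0.10 log units; within the scatter) from compound 2 to compound 4, 1.3-fold (0.10 log units) apart, within the scatter of two such steps Across these four compounds, each change therefore carries from one core to the other with its size intact, but this rests on only two cores per change and shows neither why the fluorines matter nor that the same would hold for other groups.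

From the compounds shown here alone, it remains open whether a single fluorine on the phenyl ring would account for the step or only part of it. Going by these compounds, it is equally open whether the carry-over would survive a different group on that aromatic carbon, such as a methoxy or a sulfonamide, or a tetrazole in place of the carboxylic acid.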